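Dihydropyridine atrial agonists: pyridyl placement and ester change

This account rests on a few compounds, and the source may have more. Where it says the series, first, only, none or still open, it means among the compounds named here.

Measured compounds:
compound 1 `CC1=NC(C)=C([N+](=O)[O-])C(c2ccccn2)/C1=C(\O)OC(C)(C)C` 1810000 nM
compound 2 `CC1=NC(C)=C([N+](=O)[O-])C(c2cccnc2)/C1=C(\O)OC(C)(C)C` 14600 nM
compound 3 `COCCO/C(O)=C1\C(C)=NC(C)=C([N+](=O)[O-])C1c1cccnc1` 49400 nM

In a functional assay (cardiac atrium) for agonist activity, with Cavia porcellus as the target (a higher number here means that more compound is needed for the effect, a lower number that less compound is needed), compound 2 gives the lowest of the three numbers. The change pyridin-2-yl in place of pyridin-3-yl on a saturated ring carbon made the step of a 120-fold higher number from compound 2 to compound 1 (2.09 log units; beyond the scatter). The change 2-methoxyethyl in place of tert-butyl on an oxygen on an unsaturated carbon made the step of a 3.4-fold higher number from compound 2 to compound 3 (0.53 log units; beyond the scatter). Compound 4 `COCCO/C(O)=C1\C(C)=NC(C)=C([N+](=O)[O-])C1c1ccccn1` is unmeasured; it differs from compound 3 by pyridin-2-yl in place of pyridin-3-yl on a saturated ring carbon, the same change as from compound 2 to compound 1 at the same place, while the cores of compound 3 and compound 4 differ from those of compound 2 and compound 1 by 2-methoxyethyl in place of tert-butyl on an oxygen on an unsaturated carbon. For the measured compounds named here, for this assay a step of about the earlier size is expected, a 91-fold higher number from compound 3 to compound 4 (1.96 log units; beyond the scatter), because a 120-fold higher number from compound 2 to compound 1 (2.09 log units; beyond the scatter) is the only measured example of this change. Compound 4 is estimated at 4500000 nM, with a range 900000 nM to 20000000 nM.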

Compound 4, half-maximal effective concentration: 9700 nM
The estimate for compound 4 lay 460-fold (2.67 log units) above the measured number; the measured number lies below the stated range.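

In this assay, pyridin-2-yl in place of pyridin-3-yl gives a 5.1-fold lower number from compound 3 to compound 4 (0.71 log units; beyond the scatter), so the change does not carry from one core to the other with its earlier size or direction: the same change on two cores in this assay, a 120-fold higher number (2.09 log units; beyond the scatter) from compound 2 to compound 1 and a 5.1-fold lower number (0.71 log units; beyond the scatter) from compound 3 to compound 4, 630-fold (2.80 log units) apart, beyond the scatter of two such steps. Likewise, 2-methoxyethyl in place of tert-butyl gives a 190-fold lower number from compound 1 to compound 4 (2.27 log units; beyond the scatter), and this step also depends on the partner group: the same change on two cores in this assay, a 3.4-fold higher number (0.53 log units; beyond the scatter) from compound 2 to compound 3 and a 190-fold lower number (2.27 log units; beyond the scatter) from compound 1 to compound 4, 630-fold (2.80 log units) apart, beyond the scatter of two such steps. The two changes therefore do not add up across these four compounds, but a single square of compounds does not show why, nor which step would be typical of the series. On these data alone, it remains open whether the reversal extends to a pyridin-4-yl group. As far as these compounds go, it is also open whether it appears with a simple ethyl chain or a longer alkoxyalkyl chain on the oxygen.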